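Same Atoms Joined Differently: A Forecast for Compound 4

The source may report more compounds than this note shows. Statements on the series, on what has been measured and on what is new or still open speak of the compounds shown alone.

Of the compounds shown here, three that share one core have been measured in a functional assay on CHO cells with adenosine receptor A1 (Homo sapiens) as the target, read by cAMP accumulation and immunoassay, with a stated time of 6 min, tested at 0.01 uM; on this read-out higher numbers stand for a weaker effect at the one concentration tested and lower numbers for a stronger effect. Compound 1 `Nc1scc(CN2CCN(c3ccccc3C(F)(F)F)CC2)c1C(=O)c1ccc(Cl)cc1` gives 0% in this assay. Compound 2 `Nc1scc(CN2CCN(c3cccc4ccccc34)CC2)c1C(=O)c1ccc(Cl)cc1` gives 8.7%. Compound 3 `Nc1scc(CN2CCN(c3cc(F)cc(F)c3)CC2)c1C(=O)c1ccc(Cl)cc1` gives -13%, the lowest of the three numbers; its nearest neighbour is compound 1, and the step of a number 13 percentage points lower from compound 1 to compound 3 (beyond the scatter) lies beyond the scatter, as does the step of a number 21.7 percentage points lower from compound 2 to compound 3 (beyond the scatter).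

Compound 4 `Nc1scc(CN2CCN(c3c(F)cccc3F)CC2)c1C(=O)c1ccc(Cl)cc1` has not yet been measured. It differs from compound 3 in one place: 2,6-difluorophenyl in place of 3,5-difluorophenyl on an amine nitrogen in a ring. The two measured steps that bear on this position, a number 13 percentage points lower from compound 1 to compound 3 (beyond the scatter) and a number 21.7 percentage points lower from compound 2 to compound 3 (beyond the scatter), each exchanged one aryl group for another and each gave a step of modest size. Going by the values given here, no measured step keeps the same atoms and only rearranges them within the group on this ring nitrogen, so the change from compound 3 to compound 4 is not directly covered by the data. A step of no more than modest size in this assay is therefore expected, with no clear direction. The expected step is a number 10 percentage points higher from compound 3 to compound 4 (within the scatter). Compound 4 is expected to give -3%, with a range from -20% to 15%.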

Compound 4, a percentage reported as activity, at one concentration (the size of the read-out at that concentration, not a potency): -12%
The estimate for compound 4 lay 9 percentage points above the measured number; low and high end bracket the measured number.
By their numbers in this assay, from the lowest: compounds 3 and 4 (each within the scatter of the next); then compounds 1 and 2 (each within the scatter of the next).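

Moving the two fluorines around the phenyl ring, with the same atoms joined differently, gives a number 1 percentage points higher from compound 3 to compound 4 (within the scatter) in this assay and is the first evidence on such a rearrangement at this position: here, 3,5-difluorophenyl and 2,6-difluorophenyl cannot be told apart. Compound 4 also separates from the two larger aryl groups, with a number 20.7 percentage points lower from compound 2 to compound 4 (beyond the scatter) and a number 12 percentage points lower from compound 1 to compound 4 (beyond the scatter) both placing the new difluorophenyl compound on the lower side, so among these four compounds both fluorine patterns sit apart from 2-(trifluoromethyl)phenyl and naphthalen-1-yl. Nothing available explains why the two fluorine patterns read alike or why they differ from the other two groups.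

A single concentration shows the size of the effect at that concentration and not potency, so the two difluorophenyl compounds could still differ at other concentrations. From the compounds shown here alone, it also remains open whether a phenyl ring carrying a single fluorine, two chlorines, a methoxy group or a nitrile on this ring nitrogen would read like compound 3 and compound 4 or like compound 1 and compound 2.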